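Fluoro in place of chloro: what compound 3 may show

A few compounds are considered here, and "the series" means these few. Any claim that something is new, unique, unknown or untested is made for them only; others in the source may bear on it.

Values so far in an ADME assay for permeability, using PAMPA, with a stated time of 3 h; a higher number here means that the compound crosses the layer faster, a lower number that the compound crosses the layer more slowly (all measured)
compound 1 `O=C(Nc1cccc([N+](=O)[O-])c1)c1cc(Cl)ccc1O` gives 19.5 10^-6 cm/s
compound 2 `O=C(Nc1cccc(Cl)c1)c1cc(Cl)ccc1O` gives 8.6 10^-6 cm/s

Compound 2 stands lowest of the two measured compounds, with compound 1 as its nearest neighbour. Compound 3 `O=C(Nc1cccc(F)c1)c1cc(Cl)ccc1O` has not yet been measured. It differs from compound 2 by fluoro in place of chloro on an aromatic carbon with fluoro in place of chloro on an aromatic carbon, meta to a large group. Going by the values given here, the only measured step that bears on this place is a 2.3-fold lower number from compound 1 to compound 2 (0.36 log units; beyond the scatter) with chloro in place of nitro. Among the compounds with values here, no measured step replaces chloro by fluoro, so this guide is weak. In this assay no step beyond the scatter is expected, and no direction can be firmly expected. The estimated step is a 1.2-fold higher number from compound 2 to compound 3 (0.07 log units; within the scatter) and it remains an expectation. For compound 3 the estimated value is 10 10^-6 cm/s with an expected range from 5 10^-6 cm/s to 20 10^-6 cm/s in repeated measurements.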

Compound 3, apparent permeability: 3.7 10^-6 cm/s
Compound 3: the middle estimate sits 2.7-fold (0.43 log units) above what was measured; measured number outside the range, below it.
By their numbers in this assay, from the lowest: compound 3; then compound 2; then compound 1.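

In this assay, fluoro in place of chloro on this aromatic carbon, meta to a large group, gave a 2.3-fold lower number from compound 2 to compound 3 (0.37 log units; beyond the scatter) and so proved to be a real change rather than a silent swap. Fluoro in place of nitro gave a 5.3-fold lower number from compound 1 to compound 3 (0.72 log units; beyond the scatter) as the wider step, so with the earlier chloro result each of the three groups now stands apart from the others beyond the scatter, with nitro highest and fluoro lowest. No evidence is available to explain this order.

The compounds shown leave open where an amine, a methoxy group or a plain hydrogen at this position would fall relative to these three. They also leave open whether the same order among nitro, chloro and fluoro would hold with a different group elsewhere on the shared core.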